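This account rests on a few compounds, and the source may have more. Where it says the series, first, only, none or still open, it means among the compounds named here.

Compound 1 has the structure `CCn1cc(-c2nc3ccccc3[nH]2)c(=O)c2cc(F)c(N3CCNCC3)cc21`. In a functional assay on U-937 cells (Homo sapiens) for cytotoxicity, read by sulforhodamine B assay, with a stated time of 48 h (on this read-out lower numbers stand for stronger inhibition and higher numbers for weaker inhibition), compound 1 gives > 10000 nM, which is a limit of the assay rather than a number. Compound 2, with the structure `CCn1cc(-c2nc3ccc([N+](=O)[O-])cc3[nH]2)c(=O)c2cc(F)c(N3CCNC(C)C3)c(F)c21`, gives > 10000 nM in this assay, again a limit. Compound 3, with the structure `CCn1cc(-c2nc3ccc([N+](=O)[O-])cc3s2)c(=O)c2cc(F)c(N3CCN(C)CC3)cc21`, gives > 10000 nM in this assay, once more a limit. For the measured compounds named here, all three values therefore rest at the limit of > 10000 nM in this assay, at which 3 of the 3 values shown sit, so no step between measured compounds can be sized, and compound 1 cannot be placed above or below the other two on these numbers.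

Compound 4, with the structure `CCn1cc(-c2nc3ccc(N)cc3[nH]2)c(=O)c2cc(F)c(N3CCNCC3)cc21`, has not yet been measured in this assay. It differs from compound 1 in one place: amino in place of hydrogen on an aromatic carbon.

With every measured value a limit, the step from compound 1 to compound 4 is expected to be none beyond the scatter, meaning a step that the limit leaves unreadable from compound 1 to compound 4. Compound 4 is accordingly estimated at about 15000 nM, expected to lie between 5000 nM and 50000 nM, and most likely to be reported again only as a limit.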

Compound 4, half-maximal inhibitory concentration: > 10000 nM
Compound 4: a limit, no number; the forecaster's own chance of this, stated with the estimate: 80%; the middle value does not contradict the limit.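

The step between compound 1 and compound 4 cannot be read, since both values are limits and not numbers: the limit of > 10000 nM in this assay, at which 4 of the 4 values shown sit.

The compounds shown leave open whether amino in place of hydrogen on an aromatic carbon has any effect, and which change to the shared core would give a readable number.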